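Shortening the alkyne chain of compound 1 by one carbon

A few compounds are considered here, and "the series" means these few. Any claim that something is new, unique, unknown or untested is made for them only; others in the source may bear on it.

Compound 1 `CCCCCCC#Cc1cn(C/C=C/CN2C(=O)c3ccccc3C2=O)c(=O)[nH]c1=O` is the stronger of the two numbered compounds in a functional assay on HeLa cells (Homo sapiens) for antiproliferative activity, read by MTT assay, with a stated time of 3 days (a lower number here means a stronger inhibitor, a higher number a weaker inhibitor), where compound 1 gives 34000 nM. Compound 2 `CCCCc1ccc(C#Cc2cn(C/C=C\CN3C(=O)c4ccccc4C3=O)c(=O)[nH]c2=O)cc1` gives 85000 nM in this assay. Compound 3 `O=C1c2ccccc2C(=O)N1C/C=C\Cn1cc(C#CCCc2ccccc2)c(=O)[nH]c1=O` reaches only the limit of this assay, > 100000 nM; that value is a limit and not a number. For the measured compounds named here, the step of an at least 1.1-fold higher number from compound 2 to compound 3 (0.07 log units; that floor lies within the scatter) is the only measured change on the triple-bonded carbon, and it rests on a limit (the limit of > 100000 nM in this assay, at which 1 of the 3 values shown sits), so its size is not fixed.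

Compound 4 `CCCCCC#Cc1cn(C/C=C/CN2C(=O)c3ccccc3C2=O)c(=O)[nH]c1=O` differs from compound 1 by hydrogen in place of methyl on a saturated chain carbon, five bonds along the chain from a triple-bonded carbon. Going by the values given here, no measured step removes a methyl from a saturated chain; the one measured step on the alkyne substituent, from compound 2 to compound 3, is small and uncertain. A change within the scatter, or a slight weakening, is therefore expected, with a 1.2-fold higher number from compound 1 to compound 4 (0.09 log units; within the scatter) as the estimated step. Compound 4 is expected to give about 42000 nM in this assay, between 17000 nM and 100000 nM.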

Compound 4, half-maximal inhibitory concentration: 91000 nM
Estimate against measurement, compound 4: 2.2-fold (0.34 log units) below; measured number inside the range.
By their numbers in this assay, from the lowest: compound 1; then compounds 2 and 4 (each within the scatter of the next). At a limit, above all of these: compound 3.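

In this assay, hydrogen in place of methyl on a saturated chain carbon, five bonds along the chain from a triple-bonded carbon, gives a 2.7-fold higher number from compound 1 to compound 4 (0.43 log units; beyond the scatter), a modest step but one beyond the scatter. Unlike the step from compound 2 to compound 3, which rests on a limit, this step has a fixed size. It shows that the number for compound 1 responds to the removal of a single carbon at the far end of the alkyne substituent.

Going by these compounds, whether a longer chain would lower the number, or a hydroxyl or an amine at the chain end would change it, remains open. How far a still shorter chain would raise the number may also be hard to size, because readings in this assay stop at a ceiling: the limit of > 100000 nM in this assay, at which 1 of the 4 values shown sits.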